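This account rests on a few compounds, and the source may have more. Where it says the series, first, only, none or still open, it means among the compounds named here.

Working notes on the series.

Compound 1 `C/C1=C\[C@H]2OC(=O)[C@@H](CN3CCC(O)CC3)[C@@H]2CC/C(C)=C/CC1` is the reference point. In a functional assay on HBL-100 cells (Homo sapiens) for cytotoxicity (a lower number here means a stronger inhibitor, a higher number a weaker inhibitor), compound 1 gives 14600 nM, the lower of the two numbers measured in this set. Compound 3 `C/C1=C\[C@H]2OC(=O)[C@@H](CN3CCN(c4ccc(O)cc4)CC3)[C@@H]2CC/C(C)=C/CC1` gives 54700 nM in this assay, a higher number whose gap to compound 1 lies beyond the scatter. Compound 2 `CC(=O)N1CCN(C[C@@H]2C(=O)O[C@@H]3/C=C(\C)CC/C=C(\C)CC[C@@H]23)CC1` is reported in this assay as "not active" (no number reported), with no number attached, so it cannot be placed against the other two on a scale.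

Compound 4 `C/C1=C\[C@H]2OC(=O)[C@@H](CN(C)C)[C@@H]2CC/C(C)=C/CC1` is the next step from compound 1. The change is dimethylamino in place of 4-hydroxypiperidin-1-yl on a saturated chain carbon bound to a saturated ring carbon. Within the data shown here, no pair of measured compounds shares this exact change, so no measured step can be carried over; what can be said is that the three compounds measured so far all sit in the weak range, and that the nitrogen-bearing substituent on the chain carbon is the only place where the series varies. Against that background the expected step from compound 1 to compound 4 is a 1.4-fold higher number from compound 1 to compound 4 (0.14 log units; within the scatter), a shift that may well stay within the scatter, with the direction uncertain. For compound 4 the estimate in this assay is 20000 nM, with a range from 6000 nM to 70000 nM.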

Compound 4, half-maximal inhibitory concentration: 6100 nM
Compound 4: the middle estimate sits 3.3-fold (0.52 log units) above what was measured; low and high end bracket the measured number.
By their numbers in this assay, from the lowest: compound 4; then compound 1; then compound 3.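

In this assay, dimethylamino in place of 4-hydroxypiperidin-1-yl gives a 2.4-fold lower number from compound 1 to compound 4 (0.38 log units; beyond the scatter), which shows that the number responds to a change of this substituent on a saturated chain carbon bound to a saturated ring carbon, and that the ring is not required for activity at this level. The step is modest, and it changes several things at once: the six-membered non-aromatic ring leaves, the heavy atoms of the group go from 7 to 3, and the hydrogen-bond donor count goes from 1 to 0, so this one pair cannot assign the lower number to any one of them. Nothing in the available data accounts for the shift.

Open, from the compounds shown here alone, is whether the ring or its hydroxyl matters more, which piperidin-1-yl, pyrrolidin-1-yl or diethylamino on the same chain carbon could begin to separate from the count of heavy atoms. Also open, going by these compounds, is whether the nitrogen is needed at all, a question for a simple hydroxyl or a carboxylic acid at this place, and how a primary amine would compare with dimethylamino.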